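This account rests on a few compounds, and the source may have more. Where it says the series, first, only, none or still open, it means among the compounds named here.

Measured so far in a functional assay on HEK293 cells for agonist activity at D(4) dopamine receptor (Homo sapiens), read by FLIPR; on this read-out higher numbers stand for an effect only at larger amounts of compound and lower numbers for an effect already at smaller amounts:
compound 1, `CCc1cccc(NC(=O)CN2CCC(c3cccc[n+]3[O-])CC2)c1`, 95 nM
compound 2, `Cc1cc(C)cc(NC(=O)CN2CCC(c3cccc[n+]3[O-])CC2)c1`, 52 nM
compound 3, `O=C(CN1CCC(c2cccc[n+]2[O-])CC1)Nc1ccc(F)cc1F`, 103 nM

On these numbers compound 3 sits nearest to compound 1 and furthest from compound 2, yet neither gap is resolved: a 1.1-fold higher number from compound 1 to compound 3 (0.04 log units; within the scatter) and a 2.0-fold higher number from compound 2 to compound 3 (0.30 log units; within the scatter). The three compounds share one core and differ only in the aryl group on the amide-type nitrogen, and all three steps among them, including a 1.8-fold lower number from compound 1 to compound 2 (0.26 log units; within the scatter), stay within the scatter.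

Compound 4 is `O=C(CN1CCC(c2cccc[n+]2[O-])CC1)Nc1cc(Cl)cc(Cl)c1`, not yet measured in this assay. The change from compound 3 is 3,5-dichlorophenyl in place of 2,4-difluorophenyl on an amide-type nitrogen. Going by the values given here, the step that bears most directly on it is the one from compound 2 to compound 3, which runs between a 3,5-disubstituted phenyl and the 2,4-difluorophenyl in the opposite direction and was within the scatter; the steps from compound 1 to compound 2 and from compound 1 to compound 3 were likewise within the scatter. No measured exchange of halogen for alkyl on this phenyl exists in the series. The expectation for compound 4 is therefore a number close to that of compound 3, at most a small move toward the number of compound 2, amounting to a 1.6-fold lower number from compound 3 to compound 4 (0.20 log units; within the scatter). The estimate for compound 4 in this assay is 65 nM, within 25 nM to 170 nM.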

Compound 4, half-maximal effective concentration: 160 nM
Compound 4: the middle estimate sits 2.5-fold (0.39 log units) below what was measured; measured number inside the range.
By their numbers in this assay, from the lowest: compounds 2, 1, 3 and 4 (each within the scatter of the next, the first and the last beyond it).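

In this assay, going by these compounds alone, 3,5-dichlorophenyl in place of 3,5-dimethylphenyl on the amide-type nitrogen gives the first step that is resolved from the scatter, a 3.1-fold higher number from compound 2 to compound 4 (0.49 log units; beyond the scatter), so the aryl group at this position can move the number measurably even when the substituent positions named in the two groups stay the same. The other two new comparisons remain unresolved, with a 1.6-fold higher number from compound 3 to compound 4 (0.19 log units; within the scatter) and a 1.7-fold higher number from compound 1 to compound 4 (0.23 log units; within the scatter), so 3,5-dichlorophenyl stands apart only from 3,5-dimethylphenyl and the resolved gap rests on this single pair. The data shown include nothing that accounts for this step.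

Still open, going by these compounds, is whether the exchange of chlorine for methyl gives a step of similar size with another arrangement on the phenyl, which a pair such as 2,4-dichlorophenyl and 2,4-dimethylphenyl would test. Also open, on these data alone, is whether a single chlorine, as in 3-chlorophenyl, or a different pair of substituents, as in 3,5-dimethoxyphenyl, would fall with compound 2 or with compound 4.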